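Permeability step from a pyrazole amide to an isoxazole amide

The source may report more compounds than this note shows. Statements on the series, on what has been measured and on what is new or still open speak of the compounds shown alone.

Of the compounds shown here, two of a shared core have been measured in an ADME assay on Caco-2 cells (Homo sapiens) for permeability, in the apical to basolateral direction, at pH 7.4; on this read-out lower numbers stand for lower permeability and higher numbers for higher permeability. Compound 1 `Cc1ccc2[nH]c(C(=O)N[C@H]3CN(S(=O)(=O)c4ccccc4)C[C@@H]3C(=O)N[C@@H]3CCCNC3)cc2c1` gives 0.04 10^-6 cm/s in this assay. Compound 2 `O=C(N[C@H]1CN(S(=O)(=O)c2ccccc2)C[C@@H]1C(=O)N[C@H]1CCCNC1)c1cc(C2CC2)n[nH]1` gives 0.39 10^-6 cm/s in this assay, the higher of the two numbers, and the gap between them lies beyond the usual scatter. Compound 3 `O=C(N[C@H]1CN(S(=O)(=O)c2ccccc2)C[C@@H]1C(=O)N[C@H]1CCCNC1)c1cc(-c2ccccc2Cl)on1` has not yet been measured; it differs from compound 2 in one place: a group of 12 heavy atoms (9 carbon, 1 nitrogen, 1 oxygen, 1 chlorine; one five-membered aromatic ring with 2 hetero atoms, one six-membered aromatic ring of carbon only) in place of a group of 8 heavy atoms (6 carbon, 2 nitrogen; one three-membered non-aromatic ring of carbon only, one five-membered aromatic ring with 2 hetero atoms), on a carbonyl carbon. Without a measured step of this kind, compound 3 is expected to rise, with a step of a 2.6-fold higher number from compound 2 to compound 3 (0.41 log units; beyond the scatter) in this assay. Compound 3 is therefore estimated at 1 10^-6 cm/s in this assay, within 0.3 10^-6 cm/s to 3.5 10^-6 cm/s.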

Compound 3, apparent permeability: 0.31 10^-6 cm/s
Estimate against measurement, compound 3: 3.2-fold (0.51 log units) above; the range from low to high includes it.
By their numbers in this assay, from the lowest: compound 1; then compounds 3 and 2 (each within the scatter of the next).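

Replacing 3-cyclopropyl-1H-pyrazol-5-yl with a group of 12 heavy atoms and 0 hydrogen-bond donors, on a carbonyl carbon whose other neighbours are amide-type nitrogen, gives a 1.3-fold lower number from compound 2 to compound 3 (0.10 log units; within the scatter) in this assay. This single pair shows that this position accepts the exchange without a read-out change beyond the scatter, even with the chlorine-bearing six-membered aromatic ring added. No measurement at hand bears on why this is so. The compounds shown leave open what a group carrying an amine or a carboxylic acid would give on this carbonyl carbon. They also leave open what the same group without its chlorine would give.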